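From pyridazin-4-yl to 1-methyl-1H-pyrazol-4-yl on the shared core

The source may report more compounds than this note shows. Statements on the series, on what has been measured and on what is new or still open speak of the compounds shown alone.

The series varies one group on the shared core. In a physicochemical assay for solubility, in phosphate buffer, with a stated time of 18 h, at pH 7 (on this read-out lower numbers stand for lower solubility and higher numbers for higher solubility), compound 1 (`CC(C)CN1C(=O)c2ccccc2[C@H](C(=O)Nc2ccc(F)c(C#N)c2)[C@H]1c1ccc(C#N)s1`), with 5-cyanothiophen-2-yl, gives 4900 nM. Compound 2 (`CC(C)CN1C(=O)c2ccccc2[C@H](C(=O)Nc2ccc(F)c(C#N)c2)[C@H]1c1ccncc1`), with pyridin-4-yl, gives 55000 nM. Compound 3 (`CC(C)CN1C(=O)c2ccccc2[C@H](C(=O)Nc2ccc(F)c(C#N)c2)[C@H]1c1ccnnc1`), with pyridazin-4-yl, gives 28000 nM.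

The pyridazin-4-yl swap shows a 2.0-fold lower number from compound 2 to compound 3 (0.29 log units; within the scatter), within the scatter, so no order is read into that pair. Replacing 5-cyanothiophen-2-yl gave larger steps, an 11-fold higher number from compound 1 to compound 2 (1.05 log units; beyond the scatter) and a 5.7-fold higher number from compound 1 to compound 3 (0.76 log units; beyond the scatter), both beyond the scatter. Compound 3 therefore sits level with the pyridin-4-yl member and apart from the 5-cyanothiophen-2-yl member.

Next is compound 4 (`CC(C)CN1C(=O)c2ccccc2[C@H](C(=O)Nc2ccc(F)c(C#N)c2)[C@H]1c1cnn(C)c1`), with 1-methyl-1H-pyrazol-4-yl in place of pyridazin-4-yl on a saturated ring carbon. Among the measured compounds shown here, no measured step makes this exact change. The nearest guide is the swap between the two groups at the high end of the series, which stayed within the scatter. The larger steps all start from 5-cyanothiophen-2-yl, which is not involved here. No step beyond the scatter is expected in this assay, and no direction is favoured. The expected step is a 1.1-fold lower number from compound 3 to compound 4 (0.05 log units; within the scatter). For the measured compounds named here, the range stays wide, as the new group has no measured precedent. For compound 4 the estimated value is 25000 nM, with an expected range of 9000 nM to 70000 nM.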

Compound 4, solubility: 36000 nM
Compound 4: middle estimate off by 1.4-fold (0.16 log units), on the low side; the range from low to high includes it.
By their numbers in this assay, from the lowest: compound 1; then compounds 3, 4 and 2 (each within the scatter of the next).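

In this assay, a five-membered aromatic ring carrying a methyl group can replace either six-membered ring on this saturated ring carbon with no readable shift (a 1.3-fold higher number from compound 3 to compound 4 (0.11 log units; within the scatter); a 1.5-fold lower number from compound 2 to compound 4 (0.18 log units; within the scatter)). Among the compounds shown here, the separation from the 5-cyanothiophen-2-yl member also holds for the new group (a 7.3-fold higher number from compound 1 to compound 4 (0.87 log units; beyond the scatter)), so compound 2, compound 3 and compound 4 now form one level group, with compound 1 the only member apart from it. No independent data bear on what lies behind this grouping.

Open, from the compounds shown here alone, is whether the separation of compound 1 follows the thiophene ring or its nitrile, a question that an unsubstituted thiophen-2-yl or a cyano-substituted pyridine at this position would help to settle. Also open, going by these compounds, is how far the level group extends beyond these aromatic rings, for example to an unmethylated 1H-pyrazol-4-yl, a saturated ring such as piperidine, or a ring bearing an amine or a carboxylic acid.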